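Amine swap on the shared core: from compound 3 to compound 4

The source may report more compounds than this note shows. Statements on the series, on what has been measured and on what is new or still open speak of the compounds shown alone.

The three measured compounds share one core and differ only in the group on the saturated ring carbon. Compound 1 `OCCC(NC1CCN(CCCc2c[nH]c3ccc(-n4cnnc4)cc23)CC1)c1ccccc1` gives 5.5 nM in an assay on CHO cells for binding affinity to 5-hydroxytryptamine receptor 1D (Homo sapiens); a lower number here means a stronger inhibitor, a higher number a weaker inhibitor. Compound 2 `NC(=O)OC[C@H](NC1CCN(CCCc2c[nH]c3ccc(-n4cnnc4)cc23)CC1)c1ccccc1` gives 4.7 nM in this assay, a step of a 1.2-fold lower number from compound 1 to compound 2 (0.07 log units; within the scatter). Compound 3 `CC#CCN(C)C1CCN(CCCc2c[nH]c3ccc(-n4cnnc4)cc23)CC1` gives 9.8 nM in this assay, the highest of the three numbers shown; its step from compound 1 is a 1.8-fold higher number from compound 1 to compound 3 (0.25 log units; within the scatter), while its gap to compound 2 lies beyond the scatter.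

Compound 4 `C[C@H](NC1CCN(CCCc2c[nH]c3ccc(-n4cnnc4)cc23)CC1)c1ccccc1` has not been measured. It differs from compound 3 in one place: (1-phenylethyl)amino in place of (but-2-yn-1-yl)(methyl)amino on a saturated ring carbon. The measured step that bears on this change is the one in the opposite direction, a 1.8-fold higher number from compound 1 to compound 3 (0.25 log units; within the scatter), where an amine carrying a phenyl group and one hydrogen-bond donor gave way to the (but-2-yn-1-yl)(methyl)amino group without leaving the scatter. Compounds 1 and 2, both carrying a phenyl-bearing amine with one hydrogen-bond donor, sit close to each other. Returning to such an amine in compound 4 is therefore expected to give a step of a 1.6-fold lower number from compound 3 to compound 4 (0.21 log units; within the scatter), toward a lower number but probably within the scatter. Compound 4 is estimated at 6 nM, with a range from 2.5 nM to 15 nM.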

Compound 4, half-maximal inhibitory concentration: 0.6 nM
For compound 4 the middle estimate is 10-fold (1.00 log units) above the measured one; the measured number lies below the stated range.
By their numbers in this assay, from the lowest: compound 4; then compounds 2, 1 and 3 (each within the scatter of the next, the first and the last beyond it).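

Notes on the series: in this assay, a 16-fold lower number from compound 3 to compound 4 (1.21 log units; beyond the scatter) is the first change at this saturated ring carbon to go clearly beyond the scatter, whereas the earlier steps from compound 1 stayed within it. The phenyl-bearing amine alone does not set the level, since the substituent on its chain also counts: hydrogen in place of carbamoyloxy gives a 7.8-fold lower number from compound 2 to compound 4 (0.89 log units; beyond the scatter), and 1-phenylethyl in place of 3-hydroxy-1-phenylpropyl gives a 9.2-fold lower number from compound 1 to compound 4 (0.96 log units; beyond the scatter), so both compound 1 and compound 2, which carry oxygen-bearing chains, sit well above compound 4. Nothing available here accounts for this gain.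

The compounds shown leave open how much of the gain belongs to the phenyl ring and how much to the loss of the but-2-yn-1-yl and methyl groups on the amine nitrogen, as compound 4 changes these together. Also open, as far as these compounds go, is how narrow the preference is at the chain carbon: whether the opposite configuration of the 1-phenylethyl group, or a 1-phenylpropyl group without the hydroxyl, stays near compound 4.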